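The compounds below may be only part of what the source reports. "The series", "measured", "known", "first", "only" and "open" are said of these compounds alone.

Compound 1 `CCN(C/C=C/C#CC(C)(C)C)Cc1cccc(OCCN(C)S(=O)(=O)c2cccs2)c1` has the lowest number of the three measured in a functional assay on HepG2 cells for inhibition of squalene monooxygenase (Homo sapiens) (on this read-out higher numbers stand for weaker inhibition and lower numbers for stronger inhibition), at 60 nM. Compound 2 `CCN(C/C=C/C#CC(C)(C)C)Cc1cccc(OCCN(C)S(=O)(=O)c2ccc(F)cc2)c1` gives 255 nM in this assay and compound 3 `CCN(C/C=C/C#CC(C)(C)C)Cc1cccc(OCCN(C)S(=O)(=O)Cc2cccs2)c1` gives 200 nM; the steps of a 4.3-fold higher number from compound 1 to compound 2 (0.63 log units; beyond the scatter) and a 3.3-fold higher number from compound 1 to compound 3 (0.52 log units; beyond the scatter) both alter the group on the sulfonyl sulfur, with a 1.3-fold lower number from compound 2 to compound 3 (0.11 log units; within the scatter) between those two. Compound 4 `CCN(C/C=C/C#CC(C)(C)C)Cc1cccc(OCCN(CC)S(=O)(=O)c2cccs2)c1` differs from compound 1 by methyl in place of hydrogen on a saturated chain carbon bound to a sulfonamide nitrogen. Going by the values given here, this change sits on the nitrogen side of the sulfonamide, not on the sulfonyl sulfur, so no measured step maps it directly; the measured steps show only modest movement at that end of the molecule. A step of a 1.1-fold higher number from compound 1 to compound 4 (0.03 log units; within the scatter) is therefore expected, none beyond the scatter. Compound 4 is estimated at 65 nM in this assay, within 25 nM to 170 nM.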

Compound 4, half-maximal inhibitory concentration: 90 nM
Compound 4: middle estimate off by 1.4-fold (0.14 log units), on the low side, and the stated range covers the measured number.
By their numbers in this assay, from the lowest: compounds 1 and 4 (each within the scatter of the next); then compounds 3 and 2 (each within the scatter of the next).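

Going by these compounds alone, on the sulfonamide nitrogen, ethyl in place of methyl is tolerated in this assay: the step of a 1.5-fold higher number from compound 1 to compound 4 (0.18 log units; within the scatter) stays within the scatter, the first reading at this end of the sulfonamide. The step of a 2.2-fold lower number from compound 3 to compound 4 (0.35 log units; beyond the scatter) exchanges the whole group on the saturated chain carbon, so it ties the difference to neither end alone. Nothing available explains either step.

Open, going by these compounds, is whether propyl, cyclopropyl or a hydrogen on that nitrogen would hold the number. Also open, on these data alone, is whether ethyl behaves alike with 4-fluorophenyl on the sulfonyl sulfur.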